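A few compounds are considered here, and "the series" means these few. Any claim that something is new, unique, unknown or untested is made for them only; others in the source may bear on it.

Measured in a functional assay on COLO 205 cells (Homo sapiens) for antiproliferative activity, read by WST assay, with a stated time of 3 days; a higher number here means a weaker inhibitor, a lower number a stronger inhibitor:
- Compound 1 `N#Cc1cc(=O)[nH]c(=O)n1[C@@H]1O[C@H](CO)[C@@H](O)[C@H]1O`: > 50000 nM (a limit)
- Compound 2 `[N-]=[N+]=Nc1cc(=O)[nH]c(=O)n1[C@@H]1O[C@H](CO)[C@@H](O)[C@H]1O`: > 50000 nM (a limit)

Compound 2 stands at > 50000 nM, which is a limit of the assay and not a number. From the compounds shown here alone, its true potency therefore remains unknown. The next compound, compound 3 `Nc1cc(=O)[nH]c(=O)n1[C@@H]1O[C@H](CO)[C@@H](O)[C@H]1O`, keeps the shared core and carries amino in place of azido on an aromatic carbon.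

Among the measured compounds shown here, the one measured step that bears on this change is a step that the two limits leave unreadable from compound 1 to compound 2. It concerns a group on the same aromatic carbon, but it offers no size to carry over. Compound 1 and compound 2 share (the limit of > 50000 nM in this assay, at which 2 of the 2 values shown sit), so no clear gain in this assay is expected, and compound 3 may well also be reported only as a limit. The expected change is a number no higher from compound 2 to compound 3 (the limit leaves the size open), with no step beyond the usual scatter foreseen. The estimated value for compound 3 is 50000 nM, with an expected range from 15000 nM to 100000 nM.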

Compound 3, half-maximal inhibitory concentration: > 50000 nM
Compound 3: a limit, no number; the forecaster's own chance of this, stated with the estimate: 85%; the middle value sits exactly at the limit.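

In this assay compound 3 gives > 50000 nM, which is a limit of the assay and not a number. No step among compound 1, compound 2 and compound 3 can therefore be read, as all three share one limit: the limit of > 50000 nM in this assay, at which 3 of the 3 values shown sit.

The compounds shown leave open how potent each one truly is, and whether cyano, azido and amino differ at all on this aromatic carbon.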